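A few compounds are considered here, and "the series" means these few. Any claim that something is new, unique, unknown or untested is made for them only; others in the source may bear on it.

Compound 3 `Nc1cc(N)c2nc(-c3ccccc3)c(Oc3ccc(F)cc3)nc2c1` carries the phenoxy linkage; in a functional assay on A549 cells (Homo sapiens) for inhibition, read by sulforhodamine B assay, with a stated time of 48 h (a higher number here means a weaker inhibitor of growth, a lower number a stronger inhibitor of growth), compound 3 gives 46800 nM, the lowest of the two numbers shown, with compound 2 `Nc1cc(N)c2nc(-c3ccccc3)c(Sc3ccc(Cl)c(Cl)c3)nc2c1` nearest at 52500 nM after a 1.1-fold lower number from compound 2 to compound 3 (0.05 log units; within the scatter). Compound 1 `COc1ccc(Sc2nc3cc(N)cc(N)c3nc2-c2ccccc2)cc1` gives only a limit in this assay, < 100000 nM. The steps a step that the limit leaves unreadable from compound 1 to compound 3 and a step that the limit leaves unreadable from compound 1 to compound 2 therefore carry no readable size (the limit of < 100000 nM in this assay, at which 1 of the 3 values shown sits). Compound 4 `Nc1cc(N)c2nc(-c3ccccc3)c(Sc3ccc(F)cc3)nc2c1` differs from compound 3 by (4-fluorophenyl)sulfanyl in place of 4-fluorophenoxy on an aromatic carbon. Among the measured compounds shown here, the single readable step, which swapped the whole sulfur-linked dichlorophenyl group for the fluorophenoxy group, stayed within the scatter, so exchanging the linking atom alone is expected to move this assay by nothing beyond the scatter. Compound 4 is estimated at 45000 nM, between 20000 nM and 100000 nM, an expected step of a 1.0-fold lower number from compound 3 to compound 4 (0.02 log units; within the scatter).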

Compound 4, concentration for total growth inhibition: 30900 nM
Estimate against measurement, compound 4: 1.5-fold (0.16 log units) above; measured number inside the range.
By their numbers in this assay, from the lowest: compounds 4, 3 and 2 (each within the scatter of the next).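

In this assay, the linking atom alone is now isolated at this position, sulfur in place of oxygen with the fluorophenyl ring kept, and it gives a 1.5-fold lower number from compound 3 to compound 4 (0.18 log units; within the scatter). On the sulfur, the change of aryl group gives a 1.7-fold lower number from compound 2 to compound 4 (0.23 log units; within the scatter), so neither single change separates these compounds beyond the scatter. The step from compound 1 to compound 4 cannot be read: the limit of < 100000 nM in this assay, at which 1 of the 4 values shown sits.

The compounds shown leave open whether an amine linker at this position, or a saturated alkyl chain in place of the aryl ring, would move the number beyond the scatter.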